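The compounds below may be only part of what the source reports. "The series", "measured", "known", "first", "only" and "open" are said of these compounds alone.

Among the measured compounds shown here, compound 3 `C=CC(=O)Nc1cccc(NC(=O)CSc2nc(Nc3cccc(OC)c3)c3ccccc3n2)c1` gives 34900 nM in a functional assay on PC-3 cells (Homo sapiens) for inhibition, read by MTT assay, with a stated time of 72 h (a higher number here means a weaker inhibitor, a lower number a stronger inhibitor), the highest of the three numbers measured so far. Compound 2 `C=CC(=O)Nc1cccc(NC(=O)CSc2nc(Nc3cccc(C)c3)c3ccccc3n2)c1` gives 29200 nM in this assay, and compound 1 `C=CC(=O)Nc1cccc(NC(=O)CSc2nc(Nc3cccc(Cl)c3)c3ccccc3n2)c1` gives 12300 nM. The gaps read a 1.2-fold higher number from compound 2 to compound 3 (0.08 log units; within the scatter) and a 2.8-fold higher number from compound 1 to compound 3 (0.45 log units; beyond the scatter), so compound 3 and compound 2 cannot be told apart, whereas compound 1 sits clearly lower. Compound 4 `C=CC(=O)Nc1cccc(NC(=O)CSc2nc(Nc3ccc(Cl)cc3)c3ccccc3n2)c1` carries 4-chlorophenyl in place of 3-methoxyphenyl on a nitrogen on an aromatic ring. The measured steps that bear on this are a 2.8-fold higher number from compound 1 to compound 3 (0.45 log units; beyond the scatter), which exchanges chloro for methoxy on an aromatic carbon, and, less directly, a 2.4-fold higher number from compound 1 to compound 2 (0.38 log units; beyond the scatter). For the measured compounds named here, compound 4 reverses the first of these in kind, but the chlorine enters as 4-chlorophenyl, not as the chloro-bearing ring of compound 1, so no measured pair covers the change exactly. A step of about a 2.3-fold lower number from compound 3 to compound 4 (0.37 log units; beyond the scatter) toward a lower number is therefore expected, with wider uncertainty than a plain reversal would carry. Compound 4 is estimated at 15000 nM, within 6000 nM to 40000 nM.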

Compound 4, half-maximal inhibitory concentration: 10800 nM
Compound 4: the middle estimate sits 1.4-fold (0.14 log units) above what was measured, within the range that was stated.
By their numbers in this assay, from the lowest: compounds 4 and 1 (each within the scatter of the next); then compounds 2 and 3 (each within the scatter of the next).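

Moving the chlorine on this ring has no readable effect in this assay: 4-chlorophenyl in place of 3-chlorophenyl gives a 1.1-fold lower number from compound 1 to compound 4 (0.06 log units; within the scatter), so compound 1 and compound 4 cannot be told apart. The 4-chlorophenyl ring also stays clear of the two rings without chlorine, with a 2.7-fold lower number from compound 2 to compound 4 (0.43 log units; beyond the scatter) and a 3.2-fold lower number from compound 3 to compound 4 (0.51 log units; beyond the scatter), so among these four compounds, both chlorine-bearing rings give lower numbers than 3-methylphenyl and 3-methoxyphenyl. No measurement at hand accounts for this split.

As far as these compounds go, whether 4-methylphenyl or 4-methoxyphenyl would match its 3-substituted partner as closely as the chlorine pair does remains open. So does the reading for this ring carrying a trifluoromethyl group, a carboxylic acid or a dimethylamino group.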